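Swapping propylamino for octylsulfanyl on a shared core

The source may hold more compounds than are shown below. What is called first, only, known or untested is meant among the compounds shown, and "the series" means these compounds.

Among the measured compounds shown here, these compounds share one core, yet none has a plain number so far. In an ADME assay on MOLT-3 cells (Homo sapiens) for cytotoxicity, with a stated time of 7 days (a lower number here means that less compound is tolerated, a higher number that more compound is tolerated), compound 1 `Nc1nc(OCC(F)(F)F)c2ncn(/C=C3/CC3(CO)CO)c2n1` gives > 20000 nM, which is a limit and not a number. Compound 2 `CC(C)Nc1nc(N)nc2c1ncn2/C=C1/CC1(CO)CO` is recorded as "not determined" (no result reported). Compound 3 `CCCNc1nc(N)nc2c1ncn2/C=C1/CC1(CO)CO` is recorded as "not determined" (no result reported), so it has no place on the scale. Compound 4 `CCCCCCCCSc1nc(N)nc2c1ncn2/C=C1/CC1(CO)CO` still awaits measurement. The change octylsulfanyl in place of propylamino on an aromatic carbon puts octylsulfanyl in place of propylamino on an aromatic carbon. For the measured compounds named here, with no measured step as a guide, a moderate move in this assay towards less compound tolerated is expected, though this is only a cautious judgement. Compound 4 is expected near 12000 nM, within an estimated range of 3000 nM to 30000 nM.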

Compound 4, half-maximal cytotoxic concentration: > 20000 nM
Compound 4: a limit, no number; the forecaster's own chance of this, stated with the estimate: 45%; middle value at least 1.6-fold (0.22 log units) away from the limit.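

No step can be read from compound 1 to compound 4, because each result is a limit and not a number: the limit of > 20000 nM in this assay, at which 2 of the 4 values shown sit.

The compounds shown leave open whether octylsulfanyl in place of 2,2,2-trifluoroethoxy changes how much compound is tolerated.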